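The compounds below may be only part of what the source reports. "The series", "measured", "known", "first", "only" and "open" are said of these compounds alone.

Compound 1 `CCCCCCCCCCCOC(=O)CCC(=O)N1CCN(CCCOc2cc3c(Nc4ccc(F)c(Cl)c4)ncnc3cc2OC)CC1` gives 93.4% in a functional assay on A549 cells (Homo sapiens) for cytotoxicity, read by MTT assay, with a stated time of 24 h, tested at 10 uM; on this read-out lower numbers stand for a stronger effect and higher numbers for a weaker effect at the one concentration tested. Compound 2 `CCCCCCCCCCCCCOC(=O)CCC(=O)N1CCN(CCCOc2cc3c(Nc4ccc(F)c(Cl)c4)ncnc3cc2OC)CC1` gives 93.7% in this assay.

Compound 2 holds the highest of the two numbers shown, though its only neighbour, compound 1, sits within the scatter of it, so the two cannot be ordered. Among the measured compounds shown here, the step of a number 0.3 percentage points higher from compound 1 to compound 2 (within the scatter) is the one measured step that bears on the change now considered. Compound 3 `CCCCCCCCCCCCCCCOC(=O)CCC(=O)N1CCN(CCCOc2cc3c(Nc4ccc(F)c(Cl)c4)ncnc3cc2OC)CC1` differs from compound 2 in one place: ethyl in place of hydrogen on a saturated chain carbon, ten or more bonds along the chain from an oxygen next to a carbonyl group. The earlier step was of the same kind, and it left the number essentially unchanged. The expected step of a number 0.2 percentage points lower from compound 2 to compound 3 (within the scatter) is therefore no change beyond the scatter in this assay, in either direction. Compound 3 is accordingly expected to give about 93.5% in this assay, with a likely range from 85% to 100%.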

Compound 3, a percentage reported as activity, at one concentration (the size of the read-out at that concentration, not a potency): 92%
Compound 3: middle estimate off by 1.5 percentage points, on the high side, within the range that was stated.
By their numbers in this assay, from the lowest: compounds 3, 1 and 2 (each within the scatter of the next).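

Ethyl in place of hydrogen on a saturated chain carbon now has a second reading in this assay: the step is a number 1.7 percentage points lower from compound 2 to compound 3 (within the scatter). Butyl in place of hydrogen at that same place, which spans all three compounds, also stays inside the scatter, as a number 1.4 percentage points lower from compound 1 to compound 3 (within the scatter), so the three compounds cannot be ordered and this part of the chain shows no measurable effect on the read-out. Nothing measured here offers an explanation for this flat response.

From the compounds shown here alone, whether a much longer chain, or an amine or a carboxylic acid at the far end of the chain, would move the number beyond the scatter remains open. So does whether a shorter chain such as methyl or propyl would read any differently in this assay.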